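Methyl to Methoxy on Two Related Cores

The source may hold more compounds than are shown below. What is called first, only, known or untested is meant among the compounds shown, and "the series" means these compounds.

Compound 1 `Cc1cccc2cc3c(nc12)-c1nc2ccccc2n1C3` and compound 2 `Cc1ccc2nc3c(cc2c1)Cn1c-3nc2ccccc21` have the same atoms joined differently; the difference between the two cores is not broken down here. In a functional assay on HT-1080 cells (Homo sapiens) for cytotoxicity, read by MTT assay, with a stated time of 72 h (a higher number here means a weaker inhibitor, a lower number a stronger inhibitor), compound 1 gives only a limit of the assay, > 100000 nM. Compound 2 gives 9300 nM in this assay. Compound 3 `COc1cccc2cc3c(nc12)-c1nc2ccccc2n1C3` carries methoxy in place of methyl on an aromatic carbon. In this assay compound 3 likewise gives only a limit, > 100000 nM. Between them stands a step that the two limits leave unreadable from compound 1 to compound 3, because of the limit of > 100000 nM in this assay, at which 2 of the 3 values shown sit. Compound 4 `COc1ccc2nc3c(cc2c1)Cn1c-3nc2ccccc21` carries the same kind of change on the core of compound 2, (methoxy in place of methyl on an aromatic carbon), though here the carbon bearing it is meta to a fused ring and para to a fused ring rather than ortho to a fused ring and meta to a fused ring. The measured step offers no readable size. The step from compound 2 to compound 4 is nonetheless expected to be small, a 1.6-fold higher number from compound 2 to compound 4 (0.21 log units; within the scatter). Compound 4 is estimated at 15000 nM, between 4000 nM and 60000 nM.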

Compound 4, half-maximal inhibitory concentration: 52300 nM
For compound 4 the middle estimate is 3.5-fold (0.54 log units) below the measured one, within the range that was stated.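

In this assay, methoxy in place of methyl on the core of compound 2 gives a 5.6-fold higher number from compound 2 to compound 4 (0.75 log units; beyond the scatter) and so a modestly weaker compound. This single readable step does not show that the change has the same size or direction on the core of compound 1. The matching step on that core cannot be read, because compound 1 and compound 3 both stand at a limit of the assay: the limit of > 100000 nM in this assay, at which 2 of the 4 values shown sit.

The compounds shown carry only methyl or methoxy on these cores. From the compounds shown here alone, how an amine, a carboxylic acid or a longer chain such as ethoxy would compare with methyl on either core remains open.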